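Fluoro for Chloro: An Expectation for Compound 3

This account rests on a few compounds, and the source may have more. Where it says the series, first, only, none or still open, it means among the compounds named here.

Measured in a functional assay on the whole organism (artery, strain albino) with Rattus norvegicus as the target, with a stated time of 360 min, at a dose of 10 mg/kg by the oral route; on this read-out higher numbers stand for more inhibition at the one dose given (going by the name of the read-out) and lower numbers for less inhibition:
Compound 1, `COc1ccc(C2N=C(SCc3ccccc3Cl)NC(C)=C2C(=O)Nc2ccc(F)cc2)cc1OC`, gives 39.2%.
Compound 2, `COc1ccc(C2N=C(SCc3ccc(Cl)cc3)NC(C)=C2C(=O)Nc2ccc(F)cc2)cc1OC`, gives 37.1%.

Among the compounds with values here, compound 2 sits beside compound 1 on this read-out; the one measured step, a number 2.1 percentage points lower from compound 1 to compound 2 (within the scatter), lies within the scatter, so the two numbers cannot be told apart. Compound 3, `COc1ccc(C2N=C(SCc3ccc(F)cc3)NC(C)=C2C(=O)Nc2ccc(F)cc2)cc1OC`, differs from compound 2 in one place: fluoro in place of chloro on an aromatic carbon. Within the data shown here, no measured step exchanges chloro for fluoro, so the only guide is the single step above, which changed the chlorophenyl substitution pattern and produced no shift beyond the scatter. On that basis the halogen swap from compound 2 to compound 3 is expected to amount to a number 1.1 percentage points lower from compound 2 to compound 3 (within the scatter), that is, no step beyond the scatter in either direction. Compound 3 is therefore estimated to give 36%, with a range of 22% to 50%.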

Compound 3, a percentage reported as inhibition, in the whole organism at one dose (the size of the read-out at that dose, not a potency): 37.1%
Compound 3: the middle estimate sits 1.1 percentage points below what was measured, and the stated range covers the measured number.
By their numbers in this assay, from the lowest: compounds 2, 3 and 1 (each within the scatter of the next).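

In this assay, within the data shown here, fluoro in place of chloro on the aromatic carbon gives no change at the digits printed from compound 2 to compound 3 (within the scatter) and is the first direct reading of a halogen exchange at this position, para to a large group. Here the read-out does not separate the two halogens. The step that changes both the halogen and its place, 2-chlorophenyl to 4-fluorophenyl, gives a number 2.1 percentage points lower from compound 1 to compound 3 (within the scatter) and so shows no separation either. Nothing available accounts for these results.

The compounds shown leave open whether a group other than a halogen at this carbon, such as an amine or a carboxylic acid, would move the number beyond the scatter. Also open, as far as these compounds go, is whether a longer chain in place of the benzyl link on the sulfur would do so.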